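A few compounds are considered here, and "the series" means these few. Any claim that something is new, unique, unknown or untested is made for them only; others in the source may bear on it.

Compound 1 `Cc1ccc(-c2cc(NO)c(C(=O)NC3CCCCC3)c(=O)o2)cc1` and compound 2 `COc1ccc(-c2cc(NO)c(C(=O)NC3CCCCC3)c(=O)o2)cc1` share one core, while compound 3 `Cc1ccc(NC(=O)c2c(NO)cc(-c3cccs3)oc2=O)cc1` and compound 4 `COc1ccc(NC(=O)c2c(NO)cc(-c3cccs3)oc2=O)cc1` share another; the difference between the two cores is not broken down here. In an ADME assay on Huh-7 cells (Homo sapiens) for cytotoxicity, with a stated time of 3 days (a higher number here means that more compound is tolerated, a lower number that less compound is tolerated), compound 1 gives 10100 nM. In this assay compound 2 gives 13900 nM. The change between them, (methoxy in place of methyl on an aromatic carbon), made the step of a 1.4-fold higher number from compound 1 to compound 2 (0.14 log units; within the scatter). For compound 3 the assay reports only a limit: in this assay compound 3 gives > 20000 nM, which is the limit of > 20000 nM in this assay, at which 1 of the 3 values shown sits. Compound 4 carries the same change, (methoxy in place of methyl on an aromatic carbon), at a place described in the same words. Because the earlier step was a 1.4-fold higher number from compound 1 to compound 2 (0.14 log units; within the scatter), a similarly small step is expected here, a step that the limit leaves unreadable from compound 3 to compound 4. Compound 4 is therefore estimated at 28000 nM, with a range from 12000 nM to 60000 nM, and the assay may again report only a limit.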

Compound 4, half-maximal cytotoxic concentration: > 20000 nM
Compound 4 gave a limit, no number; the forecaster's own chance of this, stated with the estimate: 70%; the middle value lies beyond the limit too.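

No step from compound 3 to compound 4 can be read in this assay, because both give a limit rather than a number: the limit of > 20000 nM in this assay, at which 2 of the 4 values shown sit.

The compounds shown leave open whether methoxy in place of methyl matters on the core of compound 3.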